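The source may hold more compounds than are shown below. What is called first, only, known or untested is meant among the compounds shown, and "the series" means these compounds.

Measured so far:
- Compound 1, `COc1ccc(/C=N\NC(=S)NC(C)(C)CCC[C@](C)(O)[C@@H]2CC=C(C)CC2)cc1`, gives 15800 nM in a functional assay on OVCAR-3 cells (Homo sapiens) for cytotoxicity, read by sulforhodamine B assay; a lower number here means a stronger inhibitor of growth, a higher number a weaker inhibitor of growth.
- Compound 2, `CC1=CC[C@@H]([C@@](C)(O)CCCC(C)(C)NC(=S)N/N=C\c2cccc([N+](=O)[O-])c2)CC1`, gives 40800 nM in this assay.

Both compounds share one core and differ only in the aromatic ring attached to the carbon that carries a double bond to nitrogen. On the numbers shown, compound 2 stands at the higher end: its nearest neighbour is compound 1, and the change from compound 1 to compound 2 gave a 2.6-fold higher number from compound 1 to compound 2 (0.41 log units; beyond the scatter), a modest step beyond the scatter.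

Compound 3, `CC1=CC[C@@H]([C@@](C)(O)CCCC(C)(C)NC(=S)N/N=C\c2ccccc2Cl)CC1`, has not yet been measured in this assay. It differs from compound 2 in that very ring: 2-chlorophenyl in place of 3-nitrophenyl on a carbon with a double bond to nitrogen. Among the measured compounds shown here, only one measured step bears on this position, the step from compound 1 to compound 2, and it was modest. A further swap of the ring is therefore expected to move the number by a similar or smaller amount; since compound 2 already holds the higher number, the more probable direction is downward, though a step within the scatter cannot be excluded. For compound 3 the expected result in this assay is 25000 nM, with a range from 10000 nM to 60000 nM, corresponding to a 1.6-fold lower number from compound 2 to compound 3 (0.21 log units; within the scatter).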

Compound 3, concentration for total growth inhibition: > 100000 nM
Compound 3 ended at the assay's limit (the forecaster's own chance of this, stated with the estimate: 10%); at least 4.0-fold (0.60 log units) between middle value and limit.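

In this assay compound 3 gives > 100000 nM, which is a limit of the assay and not a number. Among the compounds shown here, until now the only step at this position was a 2.6-fold higher number from compound 1 to compound 2 (0.41 log units; beyond the scatter); the new result adds an at least 2.4-fold higher number from compound 2 to compound 3 (0.38 log units; beyond the scatter) and an at least 6.3-fold higher number from compound 1 to compound 3 (0.80 log units; beyond the scatter), and both sizes are minimums, since one end of each step is a limit. Of the three compounds, compound 3, with its 2-chlorophenyl, is the weakest inhibitor of growth, so a change confined to the ring on the carbon with a double bond to nitrogen is enough to carry a compound with this shared core to the end of the readable range: the limit of > 100000 nM in this assay, at which 1 of the 3 values shown sits.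

The three rings differ both in the group they carry and in where it sits, so these compounds cannot separate the effect of the chlorine itself from the effect of its place on the ring. Also open, from the compounds shown here alone, is how the number would respond to a ring carrying an amine or a carboxylic acid, or to an unsubstituted phenyl at this position.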